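A Cyclobutyl Amide on the Ring Nitrogen

A few compounds are considered here, and "the series" means these few. Any claim that something is new, unique, unknown or untested is made for them only; others in the source may bear on it.

Compound 1 `COc1ccccc1C#Cc1nc2c(s1)C(=O)NCC2` gives only a limit in an assay on HEK293 cells for positive allosteric modulation of metabotropic glutamate receptor 5 (Homo sapiens), read by FLIPR, with a stated time of 1 h (a lower number here means that less compound is needed, a higher number that more compound is needed for the effect), reported as > 10000 nM. That value is the limit of > 10000 nM in this assay, at which 1 of the 2 values shown sits. Within the data shown here, compound 2 `CN1CCc2nc(C#Cc3ccccc3)sc2C1` gives the only number in this assay, namely 34 nM. Compound 3 `O=C(C1CCC1)N1CCc2nc(C#Cc3ccccc3)sc2C1` differs from compound 2 in one place: cyclobutylcarbonyl in place of methyl on an amine nitrogen in a ring. Among the measured compounds shown here, no step between measured compounds is available to set the size of such a change. The step of a 1.8-fold higher number from compound 2 to compound 3 (0.25 log units; within the scatter) is expected to be small, not clearly beyond the scatter of this assay. Compound 3 is therefore estimated at 60 nM, within a range from 15 nM to 400 nM.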

Compound 3, half-maximal effective concentration: > 10000 nM
Compound 3: a limit, no number; the forecaster's own chance of this, stated with the estimate: 10%; at least 160-fold (2.22 log units) between middle value and limit.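

The amine nitrogen in the ring proves far from indifferent to what it carries: in this assay, cyclobutylcarbonyl in place of methyl gives an at least 290-fold higher number from compound 2 to compound 3 (2.46 log units; beyond the scatter). Compound 3 gives only a limit, not a number: the limit of > 10000 nM in this assay, at which 2 of the 3 values shown sit.

Methyl thus remains the only group at this position with a number behind it. As far as these compounds go, it stays open whether the step comes with the carbonyl or with the four-membered ring. An acetyl group, a cyclobutyl bonded directly to the nitrogen, or a longer alkyl chain could separate the two.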